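Changing the aryl group on an amide-type nitrogen

The compounds below may be only part of what the source reports. "The series", "measured", "known", "first", "only" and "open" are said of these compounds alone.

Among the measured compounds shown here, in a functional assay on HT-29 cells (Homo sapiens) for cytotoxicity, read by MTT assay, with a stated time of 72 h (on this read-out higher numbers stand for weaker inhibition and lower numbers for stronger inhibition), compound 3 `O=C(CN1CCN(c2nnc(Cc3ccncc3)c3ccccc23)CC1)Nc1ccc(F)c(Cl)c1` gives the lowest number so far, 880 nM. Compound 2 `Cc1ccc(NC(=O)CN2CCN(c3nnc(Cc4ccncc4)c4ccccc34)CC2)c(C)c1` gives 1930 nM, and compound 1 `COc1ccc(NC(=O)CN2CCN(c3nnc(Cc4ccncc4)c4ccccc34)CC2)cc1OC` gives a much higher 40100 nM. All three share one core and differ only in the group on an amide-type nitrogen.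

Compound 4 `O=C(CN1CCN(c2nnc(Cc3ccncc3)c3ccccc23)CC1)Nc1c(F)cccc1F`, not yet measured, changes that same place: 2,6-difluorophenyl in place of 3-chloro-4-fluorophenyl (2,6-difluorophenyl in place of 3-chloro-4-fluorophenyl on an amide-type nitrogen).

For the measured compounds named here, three measured steps bear on this swap. Two are large, a 21-fold lower number from compound 1 to compound 2 (1.32 log units; beyond the scatter) and a 46-fold lower number from compound 1 to compound 3 (1.66 log units; beyond the scatter), so this group can matter greatly. Both start from the 3,4-dimethoxyphenyl of compound 1, which compound 4 does not carry. The closer guide is the modest 2.2-fold lower number from compound 2 to compound 3 (0.34 log units; beyond the scatter). Going by the values given here, no measured compound carries 2,6-difluorophenyl, so the direction is uncertain, but compound 3 already sits lowest at 880 nM, leaving a modest rise as the likelier outcome.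

The expected change is a 2.3-fold higher number from compound 3 to compound 4 (0.36 log units; beyond the scatter). Compound 4 is estimated at 2000 nM, with an expected range from 600 nM to 9000 nM.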

Compound 4, half-maximal inhibitory concentration: 28700 nM
Beside the measured number, compound 4's estimate is 14-fold (1.16 log units) below it; the measured number lies above the stated range.
By their numbers in this assay, from the lowest: compound 3; then compound 2; then compounds 4 and 1 (each within the scatter of the next).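

In this assay, fluorine on the phenyl ring does not by itself give a low number: 2,6-difluorophenyl and 3-chloro-4-fluorophenyl have the same count of heavy atoms and hydrogen-bond donors and acceptors, yet the exchange produces a large rise (a 33-fold higher number from compound 3 to compound 4 (1.51 log units; beyond the scatter)), and the rise against the 2,4-dimethylphenyl group is also large (a 15-fold higher number from compound 2 to compound 4 (1.17 log units; beyond the scatter)). The 2,6-difluorophenyl and 3,4-dimethoxyphenyl groups cannot be told apart here (a 1.4-fold lower number from compound 1 to compound 4 (0.15 log units; within the scatter)), so two quite different groups share the weak end of this short series. Nothing available explains why the 2,6-difluorophenyl group behaves this way.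

The compounds shown leave open how a plain phenyl or a phenyl carrying a single fluorine would compare. They also leave open whether an amine on the ring would keep the number low.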